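Extending a Fluoromethoxy Group on an Aromatic Benzoate Ester

A few compounds are considered here, and "the series" means these few. Any claim that something is new, unique, unknown or untested is made for them only; others in the source may bear on it.

Compound 2 `CCCCN1CCC(COC(=O)c2ccc(N)c(OCF)c2)CC1` gives the lowest number of the two measured compounds in an assay on membranes from striatum for displacement of a labelled ligand from 5-hydroxytryptamine receptor 4 (Cavia porcellus) (a higher number here means a weaker inhibitor, a lower number a stronger inhibitor), where compound 2 gives 0.334 nM. Compound 1 `CCCN1CCC(COC(=O)c2ccc(N)c(OC)c2)CC1` differs from it in more than one place, and in this assay compound 1 gives 0.901 nM. Compound 3 `CCCCN1CCC(COC(=O)c2ccc(N)c(OCCF)c2)CC1` is not yet measured and carries one change against compound 2: fluoromethyl in place of fluoro on a saturated chain carbon bound to an oxygen on an aromatic ring. Within the data shown here, no measured pair shows this same change, so no step can be read from the data. The expected step in this assay is a 1.5-fold higher number from compound 2 to compound 3 (0.18 log units; within the scatter), small and within the usual scatter. Compound 3 is estimated at 0.5 nM, between 0.15 nM and 1.6 nM.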

Compound 3, inhibition constant: 0.215 nM
Compound 3: the middle estimate sits 2.3-fold (0.37 log units) above what was measured, and the stated range covers the measured number.
By their numbers in this assay, from the lowest: compounds 3 and 2 (each within the scatter of the next); then compound 1.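

In this assay the swap of fluoromethoxy for 2-fluoroethoxy gives a 1.6-fold lower number from compound 2 to compound 3 (0.19 log units; within the scatter) and so makes no difference that this assay can resolve. This position therefore accepts one more chain carbon between the oxygen and the fluorine, and both compounds keep numbers well under what the estimate's upper bound allowed. Nothing available explains why the extra carbon leaves the number so little changed.

The compounds shown leave open how a longer chain such as 3-fluoropropoxy would fare here. They also leave open what a plain ethoxy group, carrying no fluorine, would do on this same butyl-bearing core.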